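Amide substituent size on the shared core: cyclohexyl step

The source may hold more compounds than are shown below. What is called first, only, known or untested is meant among the compounds shown, and "the series" means these compounds.

Measured compounds in an assay on HEK293 cells for negative allosteric modulation of metabotropic glutamate receptor 5 (Homo sapiens), read by FLIPR, with a stated time of 1 h; a lower number here means a stronger inhibitor, a higher number a weaker inhibitor:
compound 1 `CCCCN1CCc2nc(C#Cc3ccccc3)sc2C1`: > 10000 nM
compound 2 `CC(=O)N1CCc2nc(C#Cc3ccccc3)sc2C1`: 90 nM
compound 3 `CC1CC(C(=O)N2CCc3nc(C#Cc4ccccc4)sc3C2)C1`: > 10000 nM

Compound 2, the acetyl amide, gives 90 nM in this assay . For compound 1 the value > 10000 nM is a limit of the assay and not a number. For compound 3 the value > 10000 nM is likewise a limit. Compound 3 thus stands at the limit of > 10000 nM in this assay, at which 2 of the 3 values shown sit, and only a limit is known for it. Its step from the acetyl amide is an at least 110-fold higher number from compound 2 to compound 3 (2.04 log units; beyond the scatter), while a step that the two limits leave unreadable from compound 1 to compound 3 cannot be read from two limits. The step of an at least 110-fold lower number from compound 1 to compound 2 (2.04 log units; beyond the scatter) sets the acetyl amide well apart from the butyl amine.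

Compound 4 `O=C(C1CCCCC1)N1CCc2nc(C#Cc3ccccc3)sc2C1` is not yet measured. The change is cyclohexyl in place of 3-methylcyclobutyl on a carbonyl carbon. The measured step that bears on it is an at least 110-fold higher number from compound 2 to compound 3 (2.04 log units; beyond the scatter), which shows that going from methyl to 3-methylcyclobutyl on the carbonyl carbon carries the value to the limit; cyclohexyl is a further non-aromatic carbon ring, as counted. Among the compounds with values here, no measured step shows a return from the limit. The expected outcome for compound 4 is therefore a value at or beyond the limit, read as a step that the limit leaves unreadable from compound 3 to compound 4, with no step beyond the scatter. Compound 4 is estimated at 15000 nM, between 3000 nM and 60000 nM.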

Compound 4, half-maximal inhibitory concentration: > 10000 nM
Compound 4 gave a limit, no number; the forecaster's own chance of this, stated with the estimate: 75%; the middle value is on the limit's open side.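

In this assay compound 4 gives > 10000 nM, which is a limit of the assay and not a number. The loss on the carbonyl carbon is therefore not confined to 3-methylcyclobutyl: cyclohexyl in place of methyl gives an at least 110-fold higher number from compound 2 to compound 4 (2.04 log units; beyond the scatter), so a six-membered carbon ring, like the four-membered one, stands well apart from the acetyl amide. The steps joining compound 4 to compound 1 and to compound 3 link two limits and cannot be read, so no order can be given among these three compounds, and the series now gathers at one end of the scale: the limit of > 10000 nM in this assay, at which 3 of the 4 values shown sit.

The compounds shown leave open where between methyl and these carbon rings the value is lost, which an ethyl, isopropyl or cyclopropyl group on the carbonyl carbon would help to place. They also leave open whether a ring of the same size that carries an oxygen atom, such as tetrahydropyranyl, or an aromatic phenyl ring in place of cyclohexyl would bring the value back from the limit.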